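The source may report more compounds than this note shows. Statements on the series, on what has been measured and on what is new or still open speak of the compounds shown alone.

In a functional assay on the whole organism for inhibition, with Rattus norvegicus as the target (a lower number here means that less compound is needed, a higher number that more compound is needed for the effect), compound 1 `CC(C)c1ccc(OC(Cc2ccc(C(F)(F)F)cc2)C(=O)O)cc1` gives 10 mg/kg. Compound 2 `CC(C)c1ccc(OC(C)(Cc2ccc(C(F)(F)F)cc2)C(=O)O)cc1` reads < 5 mg/kg, which is a limit of the assay and not a number. Compound 3 `CC(C)c1ccc(OC(C)(Cc2cccc(Cl)c2)C(=O)O)cc1` gives 5 mg/kg. Within the data shown here, the only measured step is an at least 2.0-fold lower number from compound 1 to compound 2 (0.30 log units; that floor lies within the scatter). It concerns methyl in place of hydrogen on a saturated chain carbon, not the aromatic substituent.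

Compound 4 `CCCCc1ccc(CC(C)(Oc2ccc(C(C)C)cc2)C(=O)O)cc1` has butyl in place of trifluoromethyl on an aromatic carbon, para to a large group: butyl in place of trifluoromethyl on an aromatic carbon. Among the measured compounds shown here, no measured step covers this exchange, so the step at the chain carbon gives no size for it. The nearest guide is compound 3, which keeps the chain methyl, carries another aromatic substituent and gives 5 mg/kg. On these data alone, on that single value, no step beyond the scatter is expected, and the direction stays open. The estimated step is a number no lower from compound 2 to compound 4 (the limit leaves the size open). For compound 4 the expected value is 5 mg/kg, with an estimated range of 2 mg/kg to 12 mg/kg.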

Compound 4, dose for half-maximal effect: 1 mg/kg
Estimate against measurement, compound 4: 5.0-fold (0.70 log units) above; measured number below the stated range.
By their numbers in this assay, from the lowest: compound 4; then compounds 3 and 1 (each within the scatter of the next).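

The step from compound 2 to compound 4 cannot be read, because the value of compound 2 is a limit and not a number: the limit of < 5 mg/kg in this assay, at which 1 of the 4 values shown sits. The compounds shown leave open how butyl and trifluoromethyl on an aromatic carbon compare in this assay.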